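A few compounds are considered here, and "the series" means these few. Any claim that something is new, unique, unknown or untested is made for them only; others in the source may bear on it.

Among the compounds with values here, compound 2 `COc1cc2c(Oc3ccc(NC(=O)c4cc(-c5ccccc5C)ccn4)cc3F)ccnc2cc1OCCCN1CCCC1` has the higher of the two numbers measured so far in a functional assay on HT-29 cells (Homo sapiens) for cytotoxicity, read by MTT assay, with a stated time of 72 h; on this read-out higher numbers stand for weaker inhibition and lower numbers for stronger inhibition. Compound 1 `COc1cc2c(Oc3ccc(NC(=O)c4cc(-c5ccccc5)ccn4)cc3F)ccnc2cc1OCCCN1CCCC1`, which carries an unsubstituted phenyl group on its shared core, gives 120 nM in this assay, whereas compound 2 gives 1150 nM. Within the data shown here, the single measured step, a 9.6-fold higher number from compound 1 to compound 2 (0.98 log units; beyond the scatter), shows that adding a methyl group to that phenyl ring weakened inhibition clearly. Compound 3 `COc1cc2c(Oc3ccc(NC(=O)c4cc(-c5ccc(F)cc5)ccn4)cc3F)ccnc2cc1OCCCN1CCCC1` has not yet been measured. The change from compound 2 to compound 3 is 4-fluorophenyl in place of 2-methylphenyl on an aromatic carbon. This removes the methyl whose addition made up the step from compound 1 to compound 2, and puts a fluorine on the ring instead, so the relevant measured step suggests that most of that weakening should be reversed, with the fluorine itself an unknown of smaller scale. Compound 3 is therefore expected to give about 150 nM, with a likely range from 50 nM to 500 nM. The estimate corresponds to an expected step of a 7.7-fold lower number from compound 2 to compound 3 (0.88 log units; beyond the scatter).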

Compound 3, half-maximal inhibitory concentration: 430 nM
Beside the measured number, compound 3's estimate is 2.9-fold (0.46 log units) below it; the range from low to high includes it.
By their numbers in this assay, from the lowest: compound 1; then compound 3; then compound 2.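

Swapping 2-methylphenyl for 4-fluorophenyl at this position, opposite the ring nitrogen, recovers only part of the loss in this assay, giving a 2.7-fold lower number from compound 2 to compound 3 (0.43 log units; beyond the scatter). The fluorine is not a neutral addition either, as it gives a 3.6-fold higher number from compound 1 to compound 3 (0.55 log units; beyond the scatter), so the unsubstituted phenyl group keeps the lowest number of the three. Among these compounds, both substituents on this phenyl ring raise the number, and no compound goes against that.

As far as these compounds go, what 4-methylphenyl or 2-fluorophenyl would give remains open, and these would help separate the kind of group from its place on the ring, as would a methoxy group or an amine on the same ring. No measurement at hand explains these differences.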